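This account rests on a few compounds, and the source may have more. Where it says the series, first, only, none or still open, it means among the compounds named here.

Of the compounds shown here, three sharing one core have been tested in a functional assay on MDA-MB-435 cells (Homo sapiens) for inhibition, read by sulforhodamine B assay, with a stated time of 48 h, tested at 10 uM; a lower number here means less inhibition, a higher number more inhibition at the concentration tested (going by the name of the read-out). Compound 1 `O=Cc1ccc(-c2cn3ccnc3c(-c3ccc4ncn(C5CCCCC5)c4c3)n2)cc1` carries a formyl group on its outer phenyl ring, and in this assay compound 1 gives 13%. Compound 2 `Fc1ccc(-c2cn3ccnc3c(-c3ccc4ncn(C5CCCCC5)c4c3)n2)cc1` carries fluoro in the same position, and compound 2 gives 1.78%. Compound 3 `Clc1ccc(-c2cn3ccnc3c(-c3ccc4ncn(C5CCCCC5)c4c3)n2)cc1` carries chloro there, and compound 3 gives 36.7%, the highest of the three numbers; the step of a number 23.7 percentage points higher from compound 1 to compound 3 (beyond the scatter) and the step of a number 34.9 percentage points higher from compound 2 to compound 3 (beyond the scatter) both lie beyond the scatter, so compound 3 stands clearly above the other two.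

Compound 4 `Brc1ccc(-c2cn3ccnc3c(-c3ccc4ncn(C5CCCCC5)c4c3)n2)cc1` is not yet measured. Its difference from compound 3 is bromo in place of chloro on an aromatic carbon. The step that bears most on this is a number 34.9 percentage points higher from compound 2 to compound 3 (beyond the scatter), where one halogen replaced another at the same place and the number rose by a large amount. Among the compounds with values here, whether a further exchange of halogen continues that rise cannot be read from the numbers, since no pair with bromo has been measured. A modest gain is therefore expected, with a real chance that the change stays within the scatter.

Compound 4 is expected to give 45% in this assay, within a range from 20% to 70%. The step of a number 8.3 percentage points higher from compound 3 to compound 4 (within the scatter) is the estimated size of this change.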

Compound 4, a percentage reported as inhibition, at one concentration (the size of the read-out at that concentration, not a potency): 58.4%
Compound 4: middle estimate off by 13.4 percentage points, on the low side; low and high end bracket the measured number.
By their numbers in this assay, from the lowest: compound 2; then compound 1; then compound 3; then compound 4.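

In this assay, replacing chloro with bromo gives a number 21.7 percentage points higher from compound 3 to compound 4 (beyond the scatter), so the rise first seen with a number 34.9 percentage points higher from compound 2 to compound 3 (beyond the scatter) carries on to a third halogen, and fluoro, chloro and bromo now line up in that order at this position, para to a large group. The whole halogen span is a number 56.6 percentage points higher from compound 2 to compound 4 (beyond the scatter), and the gap to the formyl compound is a number 45.4 percentage points higher from compound 1 to compound 4 (beyond the scatter), which places compound 4 clearly above the other three and shows that exchanging one atom here can move the read-out a long way; compound 1, which carries no halogen at this place, stands outside this order. Nothing available explains why the number climbs along this series.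

Still open, from the compounds shown here alone, is whether the climb continues to iodo, and whether it belongs to halogens alone or would also appear with an amine, a carboxylic acid or a methoxy group at this place. Also open, going by these compounds, is whether the same order would hold at other concentrations, or with a different group elsewhere on the shared core.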